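Hydroxy Groups on the Benzyl Ring and Cytotoxicity

The compounds below may be only part of what the source reports. "The series", "measured", "known", "first", "only" and "open" are said of these compounds alone.

In a functional assay on P388 cells (Mus musculus) for cytotoxicity (a lower number here means a stronger inhibitor, a higher number a weaker inhibitor), compound 1 `Cc1cc(-c2c(F)cc3c(=O)c(Cc4ccccc4)cn(C4CC4)c3c2F)cc(C)n1` gives 7300 nM, compound 2 `Cc1cc(-c2c(F)cc3c(=O)c(Cc4ccc(O)cc4O)cn(C4CC4)c3c2F)cc(C)n1` gives 210 nM, and compound 3 `Cc1cc(-c2c(F)cc3c(=O)c(Cc4c(O)cc(O)cc4O)cn(C4CC4)c3c2F)cc(C)n1` gives 470 nM, the middle of these numbers. The next structure, compound 4 `Cc1cc(-c2c(F)cc3c(=O)c(Cc4cc(O)ccc4O)cn(C4CC4)c3c2F)cc(C)n1`, differs from compound 3 thus: 2,5-dihydroxyphenyl in place of 2,4,6-trihydroxyphenyl on a saturated chain carbon bound to an aromatic carbon. It has 2,5-dihydroxyphenyl in place of 2,4,6-trihydroxyphenyl on a saturated chain carbon bound to an aromatic carbon. Hydroxy groups on phenyl gave large steps, a 35-fold lower number from compound 1 to compound 2 (1.54 log units; beyond the scatter) and a 16-fold lower number from compound 1 to compound 3 (1.19 log units; beyond the scatter), while one further hydroxy gave only a modest step, a 2.2-fold higher number from compound 2 to compound 3 (0.35 log units; beyond the scatter). Compound 4 is a dihydroxyphenyl compound like compound 2, so a small downward change is expected, possibly none beyond the scatter. The expected step is a 1.5-fold lower number from compound 3 to compound 4 (0.17 log units; within the scatter). The estimated value for compound 4 is 320 nM, within an expected range of 100 nM to 1200 nM.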

Compound 4, half-maximal inhibitory concentration: 360 nM
Beside the measured number, compound 4's estimate is 1.1-fold (0.05 log units) below it; the measured number falls inside the stated range.
By their numbers in this assay, from the lowest: compounds 2, 4 and 3 (each within the scatter of the next, the first and the last beyond it); then compound 1.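

Changing to 2,5-dihydroxyphenyl keeps the large gain over plain phenyl (a 20-fold lower number from compound 1 to compound 4 (1.31 log units; beyond the scatter)), so among the three hydroxy patterns shown, the gain at this place does not rest on a single arrangement. The other two hydroxy compounds cannot be told apart from compound 4 (a 1.3-fold lower number from compound 3 to compound 4 (0.12 log units; within the scatter); a 1.7-fold higher number from compound 2 to compound 4 (0.23 log units; within the scatter)). Nothing available explains why these hydroxy compounds behave alike.

On these data alone, it remains open whether a single hydroxy group would be enough. A methoxy group or an amine in place of the hydroxy groups is also untested among the compounds shown here.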